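Changing the Fluoro Group of Compound 2 to Amino

The source may report more compounds than this note shows. Statements on the series, on what has been measured and on what is new or still open speak of the compounds shown alone.

compound 1 `COc1cc(C(=O)c2cn(-c3ccc(F)cc3)cc2-c2ccccc2F)cc(OC)c1OC`: 39 nM
compound 2 `COc1cc(C(=O)c2cn(-c3ccc(F)cc3)cc2-c2cccc([N+](=O)[O-])c2)cc(OC)c1OC`: 440 nM
compound 3 `COc1cc(C(=O)c2cn(-c3ccc(F)cc3)cc2-c2ccc([N+](=O)[O-])cc2)cc(OC)c1OC`: 240 nM

In a functional assay on MCF7 cells (Homo sapiens) for cytotoxicity, read by MTT assay, with a stated time of 96 h (on this read-out lower numbers stand for stronger inhibition and higher numbers for weaker inhibition), compound 2 gives 440 nM, which is within the scatter of compound 3 (a 1.8-fold lower number from compound 2 to compound 3 (0.26 log units; within the scatter)) but clearly above compound 1 (an 11-fold higher number from compound 1 to compound 2 (1.05 log units; beyond the scatter)). Compound 4 `COc1cc(C(=O)c2cn(-c3ccc(N)cc3)cc2-c2cccc([N+](=O)[O-])c2)cc(OC)c1OC` is not yet measured. It differs from compound 2 in one place: amino in place of fluoro on an aromatic carbon, amino in place of fluoro, para to a large group. Among the compounds with values here, no measured step changes that 4-fluorophenyl group. The steps of an 11-fold higher number from compound 1 to compound 2 (1.05 log units; beyond the scatter) and a 6.2-fold higher number from compound 1 to compound 3 (0.79 log units; beyond the scatter) concern the other aryl group, so they show only that this series can move and give no direction here. In this assay, the estimated step is therefore small, a 1.8-fold lower number from compound 2 to compound 4 (0.25 log units; within the scatter). The expected value for compound 4 is 250 nM, with a wide range of 50 nM to 900 nM.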

Compound 4, half-maximal inhibitory concentration: 260 nM
Beside the measured number, compound 4's estimate is 1.0-fold (0.02 log units) below it, and the stated range covers the measured number.
By their numbers in this assay, from the lowest: compound 1; then compounds 3, 4 and 2 (each within the scatter of the next).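

Within the data shown here, this is the first reading at the 4-fluorophenyl group, since every earlier step concerned the other aryl group. In this assay, going to 4-aminophenyl with the 3-nitrophenyl group held fixed gives a 1.7-fold lower number from compound 2 to compound 4 (0.23 log units; within the scatter), so for this pair the position tolerates amino in place of fluoro, even though amino brings a hydrogen-bond donor and acceptor that fluoro lacks. Nothing available explains this outcome.

The compounds shown leave open whether a carboxylic acid or an acetamide here would stay as close to compound 2. They also leave open whether the same change would read alike alongside the 2-fluorophenyl group of compound 1.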